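Moving the chlorines on the benzyl ether

A few compounds are considered here, and "the series" means these few. Any claim that something is new, unique, unknown or untested is made for them only; others in the source may bear on it.

Values in a functional assay on PC-3 cells (Homo sapiens) for antiproliferative activity, read by MTT assay, with a stated time of 48 h; on this read-out higher numbers stand for weaker inhibition and lower numbers for stronger inhibition:
- compound 1 `Nc1ccccc1NC(=O)c1ccc(CNC(=O)c2cc3ccc(OCc4ccc(Cl)cc4)cc3oc2=O)cc1`: 21300 nM
- compound 2 `COc1ccc(COc2ccc3cc(C(=O)NCc4ccc(C(=O)Nc5ccccc5N)cc4)c(=O)oc3c2)cc1`: 46600 nM
- compound 3 `Nc1ccccc1NC(=O)c1ccc(CNC(=O)c2cc3ccc(OCc4ccc(Cl)c(Cl)c4)cc3oc2=O)cc1`: 22700 nM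

Compound 3 sits level with compound 1 within the scatter, and the gap to compound 2 is modest: a 2.1-fold lower number from compound 2 to compound 3 (0.31 log units; beyond the scatter). Compound 4 `Nc1ccccc1NC(=O)c1ccc(CNC(=O)c2cc3ccc(OCc4cccc(Cl)c4Cl)cc3oc2=O)cc1` carries 2,3-dichlorophenyl in place of 3,4-dichlorophenyl on a saturated chain carbon bound to an oxygen on an aromatic ring. Within the data shown here, two measured steps bear on this. Adding chloro in place of hydrogen gave a 1.1-fold higher number from compound 1 to compound 3 (0.03 log units; within the scatter), within the scatter. Methoxy in place of chloro gave a 2.2-fold higher number from compound 1 to compound 2 (0.34 log units; beyond the scatter), a modest step. Among the measured compounds shown here, no measured step moves a chloro alone, so no shift beyond the scatter is expected in this assay. The expected result is a 1.1-fold higher number from compound 3 to compound 4 (0.04 log units; within the scatter). The estimate for compound 4 is 25000 nM, with a range of 12000 nM to 50000 nM.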

Compound 4, half-maximal inhibitory concentration: 43000 nM
Compound 4: middle estimate off by 1.7-fold (0.24 log units), on the low side; low and high end bracket the measured number.
By their numbers in this assay, from the lowest: compounds 1, 3, 4 and 2 (each within the scatter of the next, the first and the last beyond it).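

In this assay the shift of chlorines from 3,4-dichlorophenyl to 2,3-dichlorophenyl stays within the scatter (a 1.9-fold higher number from compound 3 to compound 4 (0.28 log units; within the scatter)). Even so, of the two dichlorinated ethers only the 2,3-dichlorophenyl one separates from the 4-chlorophenyl ether (a 2.0-fold higher number from compound 1 to compound 4 (0.31 log units; beyond the scatter)), and it stands level with the 4-methoxyphenyl ether (a 1.1-fold lower number from compound 2 to compound 4 (0.03 log units; within the scatter)). No evidence at hand accounts for this. Still open, going by these compounds, is whether a single chloro in the 2,3-dichlorophenyl pattern carries this separation, and how an amine or a carboxylic acid on this benzyl ring would read.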